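Dimethylamino for Phenoxy on an Aromatic Carbon

The source may report more compounds than this note shows. Statements on the series, on what has been measured and on what is new or still open speak of the compounds shown alone.

Compound 2 `Cc1cc(O)cc(-c2nn(CC#N)cc2-c2ccnc(-c3ccc(Oc4ccccc4)cc3)c2)c1` and compound 1 `COc1cc(C)cc(-c2c(-c3ccnc(-c4ccc(C(C)=O)cc4)c3)cnn2CC#N)c1` share one core. In a functional assay on LOX IMVI cells (Homo sapiens) for cytotoxicity, read by sulforhodamine B assay, with a stated time of 48 h, tested at 0.01 uM (a lower number here means a stronger effect, a higher number a weaker effect of the compound at the concentration tested), compound 1 gives 105%, and compound 2 gives 101%, a reading within the scatter of compound 1. Compound 3 `Cc1cc(O)cc(-c2nn(CC#N)cc2-c2ccnc(-c3ccc(N(C)C)cc3)c2)c1` has not yet been measured; it differs from compound 2 in this way: dimethylamino in place of phenoxy on an aromatic carbon. Within the data shown here, no step between measured compounds is available. The step is expected to be a number 1 percentage points lower from compound 2 to compound 3 (within the scatter), none beyond the scatter, because compound 2 already gives 101% near full activity. In this assay compound 3 is therefore expected to give 100%, ranging from 85% to 115%.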

Compound 3, a percentage reported as activity, at one concentration (the size of the read-out at that concentration, not a potency): 104%
Compound 3: the middle estimate sits 4 percentage points below what was measured; measured number inside the range.
By their numbers in this assay, from the lowest: compounds 2, 3 and 1 (each within the scatter of the next).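

In this assay, putting dimethylamino in place of phenoxy gives a number 3 percentage points higher from compound 2 to compound 3 (within the scatter). At this aromatic carbon, para to a large group, removing the six-membered aromatic ring of the phenoxy therefore leaves the reading within the scatter, so that ring shows no measurable contribution at this single concentration. No measurement shown accounts for this reading. On these data alone, whether a carboxylic acid or a morpholine ring at this place would move the reading beyond the scatter stays open. So does whether compound 2 and compound 3 would differ at higher concentrations.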